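Replacing the Bromophenyl Group of Compound 2

A few compounds are considered here, and "the series" means these few. Any claim that something is new, unique, unknown or untested is made for them only; others in the source may bear on it.

Of the compounds shown here, two have been measured in a functional assay on HeLa cells (Homo sapiens) for antiproliferative activity, read by MTT assay, with a stated time of 72 h; on this read-out lower numbers stand for stronger inhibition and higher numbers for weaker inhibition. Compound 1, `O=C1O/C(=C\Cn2cc(-c3ccc(Br)cc3)nn2)C(OCc2ccccc2)=C1OCc1ccccc1`, gives 24300 nM in this assay. Compound 2, `O=C1O[C@H]([C@@H](O)Cn2cc(-c3ccc(Br)cc3)nn2)C(OCc2ccccc2)=C1OCc1ccccc1`, gives 3910 nM in this assay. Compound 2 thus stands at the lowest of the two numbers; its nearest neighbour is compound 1, whose number is higher by a margin beyond the usual scatter. Among the measured compounds shown here, no pair of measured compounds differs in a single place, so no step between measured compounds can be read from these numbers.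

Compound 3, `O=C1O[C@H]([C@@H](O)Cn2cc(-c3cc(F)cc(F)c3)nn2)C(OCc2ccccc2)=C1OCc1ccccc1`, is not yet measured. It differs from compound 2 as follows: 3,5-difluorophenyl in place of 4-bromophenyl on an aromatic carbon. For the measured compounds named here, nothing among the measured compounds shows what this kind of exchange does here, since the only measured pair differs elsewhere in the molecule. The step from compound 2 to compound 3 is therefore expected to be small, with no firm direction, and may well lie within the scatter. The expected step is a 1.3-fold higher number from compound 2 to compound 3 (0.11 log units; within the scatter). Compound 3 is expected to give about 5000 nM in this assay, within a range from 1500 nM to 16000 nM.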

Compound 3, half-maximal inhibitory concentration: 40800 nM
For compound 3 the middle estimate is 8.2-fold (0.91 log units) below the measured one; the measured number lies above the stated range.
By their numbers in this assay, from the lowest: compound 2; then compounds 1 and 3 (each within the scatter of the next).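

In this assay, among the compounds shown here, the group on the five-membered aromatic ring with 3 nitrogen proves to matter: 3,5-difluorophenyl in place of 4-bromophenyl gives a 10-fold higher number from compound 2 to compound 3 (1.02 log units; beyond the scatter), a large step beyond the scatter and the first reading at this position, as the earlier compounds both carried 4-bromophenyl. The two groups have the same counted features, each with one six-membered aromatic ring of carbon only, no hydrogen-bond donors or acceptors and no net charge, so these counts do not separate them, although the read-out does. Nothing measured here accounts for the weaker inhibition, and no explanation can be given for the size of the step.

The exchange removes the bromine and introduces two fluorines in one move, so compound 2 and compound 3 alone cannot show which of these changes carries the step. As far as these compounds go, whether 4-bromophenyl is unusually favourable at this position also remains open, and plain phenyl, 4-chlorophenyl or 4-methoxyphenyl on the same carbon would be needed to place it among its neighbours.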